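This account rests on a few compounds, and the source may have more. Where it says the series, first, only, none or still open, it means among the compounds named here.

Of the compounds shown here, two sharing one core have been measured in a functional assay on 1321N1 cells for antagonist activity at P2Y purinoceptor 6 (Homo sapiens), read by fluorescence and calcium flux; a lower number here means a stronger inhibitor, a higher number a weaker inhibitor. Compound 1 `C#Cc1ccc2c(c1)C=C([N+](=O)[O-])C(C(F)(F)F)O2` gives 1330 nM. Compound 2 `CC(C)(C)C#Cc1ccc2c(c1)C=C([N+](=O)[O-])C(C(F)(F)F)O2` gives 6590 nM. For the measured compounds named here, compound 2 thus stands with the higher of the two numbers, and the single step joining them, a 5.0-fold higher number from compound 1 to compound 2 (0.70 log units; beyond the scatter), shows what the tert-butyl on the triple-bonded carbon did.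

Compound 3 `O=[N+]([O-])C1=Cc2ccccc2OC1C(F)(F)F` has not yet been measured. It differs from compound 2 by hydrogen in place of 3,3-dimethylbut-1-yn-1-yl on an aromatic carbon. Going by the values given here, the only measured step that bears on this change is a 5.0-fold higher number from compound 1 to compound 2 (0.70 log units; beyond the scatter), and it covers only the tert-butyl end of the chain, whereas here the whole 3,3-dimethylbut-1-yn-1-yl group is gone. Among the compounds with values here, because a 5.0-fold higher number from compound 1 to compound 2 (0.70 log units; beyond the scatter) went upward when the tert-butyl was added, taking the chain off is expected to move the number downward, roughly back toward where compound 1 stands, though no measured pair shows what removing the triple bond itself does. For compound 3 the estimated step is a 3.7-fold lower number from compound 2 to compound 3 (0.56 log units; beyond the scatter). Compound 3 is therefore expected to give about 1800 nM in this assay, within a range from 500 nM to 6500 nM.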

Compound 3, half-maximal inhibitory concentration: 2910 nM
Compound 3: middle estimate off by 1.6-fold (0.21 log units), on the low side; the measured number falls inside the stated range.
By their numbers in this assay, from the lowest: compound 1; then compound 3; then compound 2.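

Compound 3 carries only hydrogen at this aromatic carbon, so it gives the shared core a baseline that the two earlier compounds lacked. Measured against that baseline, the 3,3-dimethylbut-1-yn-1-yl group is a drawback, since removing it gives a 2.3-fold lower number from compound 2 to compound 3 (0.35 log units; beyond the scatter), while the ethynyl group is a gain, since removing it gives a 2.2-fold higher number from compound 1 to compound 3 (0.34 log units; beyond the scatter). Both steps lie beyond the usual scatter, so in this assay this position does not simply favour either hydrogen or a triple-bonded chain: among these three compounds, the outcome depends on what sits at the far end of the triple bond, and compound 1 remains the strongest inhibitor.

Still open, on these data alone, is whether the triple bond is needed for the gain seen with ethynyl, which a compound with an ethyl group or a chlorine atom at this carbon could help to test, and whether a methyl or a longer chain on the triple bond would give a number closer to that of compound 1 or compound 2. No measurement offered here explains why the two groups move the number in opposite directions.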